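Thiophene-to-phenyl exchange on the shared core

This account rests on a few compounds, and the source may have more. Where it says the series, first, only, none or still open, it means among the compounds named here.

Values in an ADME assay on HEK293 cells (Homo sapiens) for cytotoxicity, read by CCK-8 assay and cell counting, with a stated time of 2 days; a higher number here means a weaker inhibitor, a lower number a stronger inhibitor:

compound 1 `Oc1cccc(-c2cc(-c3ccc(Cl)cc3)nc(-c3cccs3)c2)c1` — 11800 nM
compound 2 `Oc1cccc(-c2cc(-c3cccs3)nc(-c3ccccc3Cl)c2)c1` — 2600 nM
compound 3 `Oc1cccc(-c2cc(-c3cccc(Cl)c3)nc(-c3cccs3)c2)c1` — 3150 nM

Compound 2 holds the lowest of the three numbers. Its nearest neighbour is compound 3, and a 1.2-fold higher number from compound 2 to compound 3 (0.08 log units; within the scatter) is within the scatter, so the two cannot be ordered. The step that separates compound 2 from compound 1 is larger: a 4.5-fold lower number from compound 1 to compound 2 (0.66 log units; beyond the scatter). The parallel step a 3.7-fold lower number from compound 1 to compound 3 (0.57 log units; beyond the scatter) is of similar size. Every measured step thus moves only the chlorine around the chlorophenyl ring.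

Compound 4 `Oc1cccc(-c2cc(-c3ccccc3)nc(-c3ccccc3Cl)c2)c1` changes a different part of the shared core: phenyl in place of thiophen-2-yl on an aromatic carbon. Among the measured compounds shown here, no measured step touches the thiophen-2-yl group, so none of the three steps bears directly on this change, and the chlorophenyl steps give no guidance on its direction. In this assay a step for compound 4 of no more than the scatter is therefore expected, with a wide range to reflect the lack of a matching precedent. Compound 4 is estimated at 3200 nM (range 1200 nM to 9000 nM). The expected step from compound 2 to compound 4 is a 1.2-fold higher number from compound 2 to compound 4 (0.09 log units; within the scatter).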

Compound 4, half-maximal inhibitory concentration: 1760 nM
Compound 4: the middle estimate sits 1.8-fold (0.26 log units) above what was measured; low and high end bracket the measured number.
By their numbers in this assay, from the lowest: compounds 4, 2 and 3 (each within the scatter of the next); then compound 1.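

In this assay, phenyl in place of thiophen-2-yl on the aromatic carbon next to the ring nitrogen gives a 1.5-fold lower number from compound 2 to compound 4 (0.17 log units; within the scatter), so compound 2 and compound 4 cannot be ordered. This is the first step shown at this position, and it indicates that, with the 2-chlorophenyl group held constant, the thiophen-2-yl group can give way to a phenyl ring with no change beyond the scatter. No available evidence accounts for this result.

Open, as far as these compounds go, is whether the same exchange would give a similar step alongside the 4-chlorophenyl group of compound 1 or the 3-chlorophenyl group of compound 3. Also open, from the compounds shown here alone, is how this position would respond to a non-aromatic group, such as an amine or a carboxylic acid, in place of the aromatic ring.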